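A few compounds are considered here, and "the series" means these few. Any claim that something is new, unique, unknown or untested is made for them only; others in the source may bear on it.

Compound 1 `COc1ccc(Nc2cc(-c3ccncc3)ncn2)cc1`: > 10000 nM
Compound 2 `FC(F)(F)Oc1ccc(Nc2ncnc3nn(Cc4cccnc4)cc23)cc1`: > 10000 nM
Compound 3 `NC(=O)c1cccc(Nc2cc(Nc3ccc(OC(F)(F)F)cc3)ncn2)c1`: > 10000 nM

In an ADME assay on BaF3 cells (Mus musculus) for cytotoxicity (on this read-out higher numbers stand for an effect only at larger amounts of compound and lower numbers for an effect already at smaller amounts), compound 1 gives > 10000 nM, which is a limit of the assay and not a measured number. Compound 2 gives > 10000 nM, also a limit. Compound 3 gives > 10000 nM, again a limit. For the measured compounds named here, compound 1 thus stands at the limit of > 10000 nM in this assay, at which 3 of the 3 values shown sit, and the two other compounds sit there as well, so no compound can be placed above or below another.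

The unmeasured compound 4 `FC(F)(F)Oc1ccc(Nc2cc(-c3ccncc3)ncn2)cc1` differs from compound 1 in one place: trifluoromethyl in place of methyl on an oxygen on an aromatic ring. Going by the values given here, no pair of measured compounds shows such a change, so its effect in this assay is not known from the data. Since compound 1 already sits at the limit of > 10000 nM in this assay, at which 3 of the 3 values shown sit, the expectation for compound 4 is no step beyond the usual scatter, with the value most likely again reported as a limit. The expected step is a step that the limit leaves unreadable from compound 1 to compound 4. Compound 4 is expected to give about 15000 nM, within a range from 5000 nM to 50000 nM.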

Compound 4, half-maximal effective concentration: > 10000 nM
Compound 4: no number, only a limit; the forecaster's own chance of this, stated with the estimate: 85%; the middle value is on the limit's open side.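

For the compounds shown here, compound 1 and compound 4 each give only a limit of the assay and not a number, so no step from methoxy to trifluoromethoxy can be read: the limit of > 10000 nM in this assay, at which 4 of the 4 values shown sit. The compounds shown leave open what concentration of any of them would give a half-maximal effect in this assay, and whether this change alters it.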